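A few compounds are considered here, and "the series" means these few. Any claim that something is new, unique, unknown or untested is made for them only; others in the source may bear on it.

In a functional assay on Caco-2 cells (Homo sapiens) for antiproliferative activity, read by MTT assay, with a stated time of 48 h; a lower number here means a stronger inhibitor, a higher number a weaker inhibitor:
compound 1 `CCn1c(C(=O)NCCCN(C)C)ccc1C(CC)(CC)c1ccc(OCCC(O)(CC)CC)c(C)c1` gives 490 nM.
compound 2 `CCn1c(C(=O)NCC#N)ccc1C(CC)(CC)c1ccc(OCCC(O)(CC)CC)c(C)c1` gives only a limit of the assay, > 50000 nM.

Compound 2 therefore sits at the limit (the limit of > 50000 nM in this assay, at which 1 of the 2 values shown sits), so no exact number is known for it. Compound 3 `CCOC(=O)C(CC(=O)OC)NC(=O)c1ccc(C(CC)(CC)c2ccc(OCCC(O)(CC)CC)c(C)c2)n1CC` differs from compound 2 on the amide-type nitrogen: a group of 11 heavy atoms (7 carbon, 4 oxygen; no ring) in place of a group of 3 heavy atoms (2 carbon, 1 nitrogen; no ring), on an amide-type nitrogen. For the measured compounds named here, the single measured step concerns this same position, an at least 100-fold higher number from compound 1 to compound 2 (2.00 log units; beyond the scatter), showing that a swap here can shift potency strongly, although one step does not fix the direction for compound 3. Compound 3 is expected to remain weak, near 30000 nM (range 3000 nM to 100000 nM), an estimated at least 1.6-fold lower number from compound 2 to compound 3 (0.22 log units; that floor lies within the scatter).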

Compound 3, half-maximal inhibitory concentration: 3020 nM
Compound 3: middle estimate off by 9.9-fold (1.00 log units), on the high side; the range from low to high includes it.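

At this amide-type nitrogen, a dimethylamino group is not required for measurable activity: the larger group of 11 heavy atoms, which has no amine, gives an at least 16-fold lower number from compound 2 to compound 3 (1.21 log units; beyond the scatter). The chain ending in dimethylamino still keeps the lead, with a 6.2-fold higher number from compound 1 to compound 3 (0.79 log units; beyond the scatter). Compound 2 has only a limit, not an exact number: the limit of > 50000 nM in this assay, at which 1 of the 3 values shown sits.

The compounds shown leave open which part of the larger group matters, since its two esters are never changed separately. Nor do they show how a carboxylic acid in place of either ester, or a shorter chain ending in dimethylamino, would behave.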